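A Methyl on the Phenyl Ring of Compound 3

The source may hold more compounds than are shown below. What is called first, only, known or untested is meant among the compounds shown, and "the series" means these compounds.

Compound 3 `COc1cc2c(Oc3ccc(NC(=O)c4nccc(-c5ccccc5)n4)cc3F)ccnc2cc1OCCCN1CCCCC1` gives the highest number of the three measured in a functional assay on NCI-H460 cells (Homo sapiens) for cytotoxicity, read by MTT assay, with a stated time of 72 h (a higher number here means a weaker inhibitor, a lower number a stronger inhibitor), namely 330 nM. Compound 1 `COc1cc2c(Oc3ccc(NC(=O)c4cc(-c5ccccc5F)ccn4)cc3F)ccnc2cc1OCCCN1CCCCC1` gives 130 nM in this assay, and compound 2 `COc1cc2c(Oc3ccc(NC(=O)c4cc(-c5ccccc5)ccn4)cc3F)ccnc2cc1OCCCN1CCCCC1` gives 120 nM. Compound 4 `COc1cc2c(Oc3ccc(NC(=O)c4nccc(-c5ccc(C)cc5)n4)cc3F)ccnc2cc1OCCCN1CCCCC1` differs from compound 3 by methyl in place of hydrogen on an aromatic carbon. The step that bears most on this is the change on the same ring between compound 1 and compound 2, a 1.1-fold lower number from compound 1 to compound 2 (0.03 log units; within the scatter), a small substituent swap that left the number essentially unchanged; the step of a 2.8-fold higher number from compound 2 to compound 3 (0.44 log units; beyond the scatter) concerns a different ring and is less informative here. Compound 4 is therefore expected to show no change at the digits printed from compound 3 to compound 4 (within the scatter), nothing beyond the scatter. The estimate for compound 4 in this assay is 330 nM, within a range of 150 nM to 750 nM.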

Compound 4, half-maximal inhibitory concentration: 230 nM
Estimate against measurement, compound 4: 1.4-fold (0.16 log units) above; measured number inside the range.
By their numbers in this assay, from the lowest: compounds 2, 1, 4 and 3 (each within the scatter of the next, the first and the last beyond it).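

In this assay, methyl in place of hydrogen on the phenyl ring, para to a large group, gives a 1.4-fold lower number from compound 3 to compound 4 (0.16 log units; within the scatter). The earlier compounds shown here showed only a change from fluoro to hydrogen on a phenyl ring, and that was with the 4-phenylpyridin-2-yl group; this step shows that a carbon group can enter the phenyl ring of the 4-phenylpyrimidin-2-yl group without a step beyond the scatter. As far as these compounds go, whether an amine, a carboxylic acid or a longer chain at this position would also stay within the scatter remains open. No measured property shown here accounts for the step.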